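A Hydroxylated Methoxyphenyl Replaces the Cyclopropylphenyl

The source may hold more compounds than are shown below. What is called first, only, known or untested is meant among the compounds shown, and "the series" means these compounds.

Compound 2 `CN(C)C(=O)c1cccnc1NCCCN1CCN(c2ccccc2C2CC2)CC1` gives 0.631 nM in a functional assay for antagonist activity at Alpha-1A adrenergic receptor (Oryctolagus cuniculus) (on this read-out lower numbers stand for tighter binding and higher numbers for weaker binding), the lowest of the two numbers measured. Compound 1 `COc1ccccc1N1CCN(CCCNc2ncccc2C(=O)N(C)C)CC1` gives 1.59 nM in this assay. Among the measured compounds shown here, the only measured step is a 2.5-fold lower number from compound 1 to compound 2 (0.40 log units; beyond the scatter). Compound 3 `COc1cc(O)ccc1N1CCN(CCCNc2ncccc2C(=O)N(C)C)CC1` differs from compound 2 by 4-hydroxy-2-methoxyphenyl in place of 2-cyclopropylphenyl on an amine nitrogen in a ring. For the measured compounds named here, this change restores the methoxy of compound 1 and adds a hydroxy whose effect no measured pair shows. Reversing the measured step should raise the number by roughly its size, so a step of about a 3.2-fold higher number from compound 2 to compound 3 (0.50 log units; beyond the scatter) is expected. Compound 3 is estimated at 2 nM, between 0.8 nM and 6 nM.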

Compound 3, dissociation constant: 12.6 nM
The estimate for compound 3 lay 6.3-fold (0.80 log units) below the measured number; measured number outside the range, above it.
By their numbers in this assay, from the lowest: compound 2; then compound 1; then compound 3.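

In this assay, among the compounds shown here, adding a hydroxy to the aromatic carbon gives a 7.9-fold higher number from compound 1 to compound 3 (0.90 log units; beyond the scatter) and so carries a cost that the earlier compounds could not reveal. The full change gives a 20-fold higher number from compound 2 to compound 3 (1.30 log units; beyond the scatter) and is wider than that hydroxy step alone, since it also gives up the cyclopropyl. Nothing available explains the loss.

On these data alone, whether an amine or a fluorine on that carbon would carry the same cost stays open. So does whether a hydroxy would cost as much on the 2-cyclopropylphenyl of compound 2.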